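The source may hold more compounds than are shown below. What is called first, only, known or untested is meant among the compounds shown, and "the series" means these compounds.

Within the data shown here, compound 2 `Cc1ccc(Cc2nc3cc(O[C@H]4CC[C@@H](C(=O)O)CC4)ccc3n2C)cc1` carries the lower of the two numbers so far: in an assay on isolated protein for inhibition of Long-chain-fatty-acid--CoA ligase 1 (Mus musculus), read by mass spectrometry, with a stated time of 90 min, in the presence of a further agent that is not named here (on this read-out higher numbers stand for weaker inhibition and lower numbers for stronger inhibition), compound 2 gives 80 nM, while compound 1 `Cc1cccc(Cc2c(C#N)c3cc(O[C@H]4CC[C@@H](C(=O)O)CC4)ccc3n2C)c1` gives 600 nM, a gap beyond the scatter. Compound 3 `Cc1cccc(Oc2nc3cc(O[C@H]4CC[C@@H](C(=O)O)CC4)ccc3n2C)c1` follows from compound 2 by one change: 3-methylphenoxy in place of 4-methylbenzyl on an aromatic carbon. Among the measured compounds shown here, no measured pair of this kind exists, so the size of the step rests on judgement alone. A moderate rise is expected, a 3.1-fold higher number from compound 2 to compound 3 (0.49 log units; beyond the scatter), larger than the scatter but short of the gap back to compound 1. Compound 3 is estimated at 250 nM, with a range of 60 nM to 1200 nM.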

Compound 3, half-maximal inhibitory concentration: 21000 nM
Compound 3: the middle estimate sits 84-fold (1.92 log units) below what was measured; the whole stated range lies below it.
By their numbers in this assay, from the lowest: compound 2; then compound 1; then compound 3.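

In this assay, the aromatic carbon between two ring nitrogen atoms proves highly sensitive to its substituent: 3-methylphenoxy in place of 4-methylbenzyl, with the heavy-atom count unchanged, gives a 260-fold higher number from compound 2 to compound 3 (2.42 log units; beyond the scatter). The swap changes the link to the aromatic ring and the place of the methyl together, so the step cannot be assigned to either change alone. Nothing available explains the size of this step.

Still open, as far as these compounds go, is whether 4-methylphenoxy or 3-methylbenzyl would separate the two changes, and how an amine link would compare with the oxygen link.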